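Fluoro Substitution on the Indolyl Group of Compound 1

The source may report more compounds than this note shows. Statements on the series, on what has been measured and on what is new or still open speak of the compounds shown alone.

Measured compounds:
Compound 1, `CC/C=C\C(=O)Nc1cc(Nc2nc(C)cc(-c3cn(C)c4ccccc34)n2)c(OC)cc1N(C)CCN(C)C`: 2050 nM in a functional assay on HepG2 cells (Homo sapiens) for antiproliferative activity, read by MTT assay, with a stated time of 72 h; on this read-out higher numbers stand for weaker inhibition and lower numbers for stronger inhibition
Compound 2, `COc1cc(N(C)CCN(C)C)c(NC(=O)/C=C\C(C)C)cc1Nc1nc(C)cc(-c2cn(C)c3ccccc23)n1`: 3550 nM in this assay

Going by the values given here, compound 1 has the lower of the two numbers in this assay, and the only neighbour is compound 2, which lies a 1.7-fold higher number from compound 1 to compound 2 (0.24 log units; within the scatter); the two values are not separated beyond the scatter. Compound 3, `CC/C=C\C(=O)Nc1cc(Nc2nc(C)cc(-c3cn(C)c4ccc(F)cc34)n2)c(OC)cc1N(C)CCN(C)C`, differs from compound 1 by fluoro in place of hydrogen on an aromatic carbon, the 1-methyl-1H-indol-3-yl group becoming 5-fluoro-1-methyl-1H-indol-3-yl. Among the compounds with values here, the single measured step, from compound 1 to compound 2, changes a saturated chain carbon of the amide side and says nothing about the aromatic ring of the indolyl group. Within the data shown here, no measured step bears on the change in hand, so in this assay no step beyond the scatter is expected in either direction. Compound 3 is therefore estimated at 2050 nM, within 900 nM to 4700 nM. The step this estimate implies is expected to be no change at the digits printed from compound 1 to compound 3 (within the scatter).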

Compound 3, half-maximal inhibitory concentration: 11000 nM
Estimate against measurement, compound 3: 5.4-fold (0.73 log units) below; the measured number lies above the stated range.
By their numbers in this assay, from the lowest: compounds 1 and 2 (each within the scatter of the next); then compound 3.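

Fluoro in place of hydrogen on this aromatic carbon of the indolyl group brings a 5.4-fold higher number from compound 1 to compound 3 (0.73 log units; beyond the scatter) in this assay and thus weaker inhibition, so the position is not indifferent to this small change. The earlier step on the amide side stayed within the scatter, which makes this the first change among the compounds shown to move the number beyond it. Nothing available here bears on what lies behind the weaker inhibition.

As far as these compounds go, whether the shift belongs to fluoro in particular or to any group replacing hydrogen on this carbon remains open, and a chloro, methoxy or nitrile group in the same place would separate those readings. From the compounds shown here alone, it also remains open whether fluoro on another carbon of the six-membered ring would give a step of similar size.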